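The source may report more compounds than this note shows. Statements on the series, on what has been measured and on what is new or still open speak of the compounds shown alone.

The measured compounds are these:
compound 1, `Nc1nc(N)nc(-c2cccc(Br)c2)n1`, which in a physicochemical assay for lipophilicity (a lower number here means a more polar compound, a higher number a more lipophilic compound), gives 2.44;
compound 2, `Nc1nc(N)nc(-c2cccc(Cl)c2)n1`, which in this assay gives 2.33;
compound 3, `Nc1nc(N)nc(-c2ccc(Cl)cc2Br)n1`, which in this assay gives 2.09.

Compound 2 differs from compound 1 in one place: chloro in place of bromo on an aromatic carbon. In this assay this change gave a number 0.11 log units lower from compound 1 to compound 2 (within the scatter). Compound 3 stands lowest of the three numbers; its distance to compound 2 is within the scatter, while its distance to compound 1 is beyond it. How the core of compound 3 differs from the core of compound 1 is not broken down here.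

Compound 4, `Nc1nc(N)nc(-c2ccc(Cl)cc2Cl)n1`, has not yet been measured. It differs from compound 3 in one place: chloro in place of bromo on an aromatic carbon. Within the data shown here, this is the same kind of change as the one from compound 1 to compound 2, but the surroundings are not the same: in compound 1 the bromo sits meta to a group of 8 heavy atoms, whereas in compound 3 it sits ortho to a group of 8 heavy atoms and meta to a chloro group. Among the compounds shown this kind of change occurs twice in all. Among the measured compounds shown here, because the one measured instance of it gave a number 0.11 log units lower from compound 1 to compound 2 (within the scatter), a step of similar size is expected for compound 4, a number 0.11 log units lower from compound 3 to compound 4 (within the scatter). Compound 4 is therefore estimated to give about 1.98 in this assay, most likely between 1.65 and 2.3.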

Compound 4, partition coefficient: 2.07
Compound 4: the middle estimate sits 0.09 log units below what was measured; measured number inside the range.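

In this assay the new pair gave a number 0.02 log units lower from compound 3 to compound 4 (within the scatter) and the earlier pair gave a number 0.11 log units lower from compound 1 to compound 2 (within the scatter) for the same change, chloro in place of bromo on an aromatic carbon. On both cores shown, then, this change stayed within the scatter, so the small step seen on the core of compound 1 also held on the core of compound 3, where the place is ortho to a group of 8 heavy atoms and meta to a chloro group. This does not show that the two steps are equal or that the change would behave alike on any other core in the series, and nothing shown here accounts for either step.

The compounds shown carry only bromo and chloro on the aromatic ring, so what this assay would give with an amine, a carboxylic acid or a longer chain on that ring remains open. Also open, going by these compounds, is whether chloro in place of bromo stays this small on cores that carry such groups, or with bromo and chloro at places other than those in these four compounds.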